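Methyl on the phenol oxygen of a quaternary ammonium

This account rests on a few compounds, and the source may have more. Where it says the series, first, only, none or still open, it means among the compounds named here.

Measured compounds in a functional assay with Cavia porcellus as the target; a lower number here means a stronger inhibitor, a higher number a weaker inhibitor:
Compound 1, `C=CC[N+](C)(C)c1ccccc1OC`: 2890 nM
Compound 2, `C=CC[N+](C)(C)c1ccc(OC)cc1`: > 3000 nM, a limit of the assay
Compound 3, `C[N+](C)(Cc1ccccc1)c1ccc(O)cc1`: > 3000 nM, a limit of the assay

Compound 3 has no number in this assay, only the limit just given, so its standing among the three cannot be fixed beyond that. Compound 2 also sits at that limit. Going by the values given here, the only numerical value belongs to compound 1, and even that lies close to the limit (the limit of > 3000 nM in this assay, at which 2 of the 3 values shown sit). Compound 4, `COc1ccc([N+](C)(C)Cc2ccccc2)cc1`, differs from compound 3 by methyl in place of hydrogen on an oxygen on an aromatic ring. Among the compounds with values here, no step between measured compounds gives a direct reading of this change. With two of three values at the limit, the expectation for this assay is no step beyond the scatter, with a fair chance that compound 4 again returns only a limit. The step from compound 3 to compound 4 is estimated at a step that the limit leaves unreadable from compound 3 to compound 4. Compound 4 is expected to give about 5000 nM, within 2500 nM to 15000 nM.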

Compound 4, half-maximal inhibitory concentration: > 3000 nM
Compound 4: no number, only a limit; the forecaster's own chance of this, stated with the estimate: 65%; the middle value is on the limit's open side.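

In this assay compound 4 gives > 3000 nM, a limit of the assay and not a number. Compound 2 and compound 3 also carry only limits, so the steps from each of them to compound 4 cannot be read. The compounds shown leave open whether methyl in place of hydrogen on an oxygen on an aromatic ring changes inhibition at all.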